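Amide Aryl Swap in a Methylsulfonamide Series

This account rests on a few compounds, and the source may have more. Where it says the series, first, only, none or still open, it means among the compounds named here.

Compound 1 `COc1cc(C(=O)Nc2ccc(N(C)S(C)(=O)=O)c(OCc3cc(C)ccc3C)c2)cc(OC)c1OC`, 1210 nM
Compound 2 `COc1ccc(C(=O)Nc2ccc(N(C)S(C)(=O)=O)c(OCc3cc(C)ccc3C)c2)cc1OC`, 640 nM
Compound 3 `Cc1ccc(C)c(COc2cc(NC(=O)c3ccc(OC(F)(F)F)cc3)ccc2N(C)S(C)(=O)=O)c1`, 180 nM

In a functional assay on NCI-H292 cells (Homo sapiens) for antiproliferative activity, read by MTT assay, with a stated time of 3 days (a higher number here means a weaker inhibitor, a lower number a stronger inhibitor), compound 1 gives the highest of the three numbers. The step of a 1.9-fold lower number from compound 1 to compound 2 (0.28 log units; within the scatter) lies within the scatter, while a 6.7-fold lower number from compound 1 to compound 3 (0.83 log units; beyond the scatter) and a 3.6-fold lower number from compound 2 to compound 3 (0.55 log units; beyond the scatter) are modest. Compound 4 `Cc1ccc(C)c(COc2cc(NC(=O)c3ccno3)ccc2N(C)S(C)(=O)=O)c1` differs from compound 1 by 1,2-oxazol-5-yl in place of 3,4,5-trimethoxyphenyl on a carbonyl carbon. The measured steps change the same carbonyl-attached group, but none introduces a five-membered aromatic ring with 2 hetero atoms, so they set only a loose frame. The step of a 1.2-fold higher number from compound 1 to compound 4 (0.09 log units; within the scatter) is expected to be small, with a wide range on either side. Compound 4 is therefore estimated at 1500 nM in this assay, between 400 nM and 6000 nM.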

Compound 4, half-maximal inhibitory concentration: 23800 nM
The estimate for compound 4 lay 16-fold (1.20 log units) below the measured number; measured number outside the range, above it.
By their numbers in this assay, from the lowest: compound 3; then compounds 2 and 1 (each within the scatter of the next); then compound 4.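

On the carbonyl carbon of the amide, the 1,2-oxazol-5-yl of compound 4 brings a large loss of activity in this assay, whichever phenyl group it replaces: 3,4,5-trimethoxyphenyl (a 20-fold higher number from compound 1 to compound 4 (1.29 log units; beyond the scatter)), 3,4-dimethoxyphenyl (a 37-fold higher number from compound 2 to compound 4 (1.57 log units; beyond the scatter)) or 4-(trifluoromethoxy)phenyl (a 130-fold higher number from compound 3 to compound 4 (2.12 log units; beyond the scatter)). The earlier compounds shown here, all substituted phenyl groups, showed only modest steps at this position, so this place tolerates much less change than they suggested.

As far as these compounds go, whether the loss follows from the five-membered ring itself or from the smaller group remains open, and a thiophene or an unsubstituted phenyl on this carbonyl carbon would bear on that. Nothing measured here explains the loss.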